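Nitro for Chloro on the Aryl Ring of Compound 3

The compounds below may be only part of what the source reports. "The series", "measured", "known", "first", "only" and "open" are said of these compounds alone.

Compound 3 `CC1=C(/C=C/C(=O)/C=C/c2ccccc2Cl)C(C)(C)CCC1` is one of three dienones that share a core and differ only in the substituted phenyl ring. In a functional assay on IMR-32 cells (Homo sapiens) for cytotoxicity, read by sulforhodamine B assay, with a stated time of 48 h (on this read-out lower numbers stand for stronger inhibition and higher numbers for weaker inhibition), compound 3 gives 13700 nM, the second highest of the three numbers. Compound 1 `CC1=C(/C=C/C(=O)/C=C/c2ccc(Cl)cc2)C(C)(C)CCC1` gives 52300 nM, and compound 2 `CC1=C(/C=C/C(=O)/C=C/c2ccc(F)cc2)C(C)(C)CCC1` gives 7400 nM. The steps among these compounds are a change of halogen, a 7.1-fold lower number from compound 1 to compound 2 (0.85 log units; beyond the scatter), a move of the same halogen to another position, a 3.8-fold lower number from compound 1 to compound 3 (0.58 log units; beyond the scatter), and a combination of both, a 1.9-fold higher number from compound 2 to compound 3 (0.27 log units; within the scatter).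

Compound 4 `CC1=C(/C=C/C(=O)/C=C/c2ccccc2[N+](=O)[O-])C(C)(C)CCC1` differs from compound 3 in one place: nitro in place of chloro on an aromatic carbon. The group sits on an aromatic carbon of a six-membered aromatic ring of carbon only, ortho to a large group. Going by the values given here, none of the measured steps exchanges a halogen for a nitro group, so no step bears directly on this change; the halogen swap in the step from compound 1 to compound 2 shows only that a change of the substituent at one site can move the number by a modest amount. In the absence of a closer precedent, compound 4 is expected to give a number near that of compound 3, with the step of a 1.2-fold lower number from compound 3 to compound 4 (0.10 log units; within the scatter) expected to remain within the scatter. Compound 4 is therefore estimated at 11000 nM, with a range from 3000 nM to 40000 nM.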

Compound 4, half-maximal inhibitory concentration: 13500 nM
The estimate for compound 4 lay 1.2-fold (0.09 log units) below the measured number; measured number inside the range.
By their numbers in this assay, from the lowest: compounds 2, 4 and 3 (each within the scatter of the next); then compound 1.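

In this assay, the exchange of chloro for nitro on this aromatic carbon, ortho to a large group, gives a 1.0-fold lower number from compound 3 to compound 4 (0.01 log units; within the scatter), so the numbers of the two compounds cannot be told apart. Going by these compounds alone, the earlier compounds carried only halogens, and this is the first sign that a non-halogen can stand at this place without a step beyond the scatter, even though nitro has 3 heavy atoms and 2 hydrogen-bond acceptors where chloro has 1 heavy atom and 0 hydrogen-bond acceptors. This flat step contrasts with the steps that started from the chloro group of compound 1, a 7.1-fold lower number from compound 1 to compound 2 (0.85 log units; beyond the scatter) and a 3.8-fold lower number from compound 1 to compound 3 (0.58 log units; beyond the scatter), but no measurement here accounts for the match between compound 3 and compound 4.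

The compounds shown leave open whether the same flat result would hold for an amine, a carboxylic acid or a methoxy group at this place. They also leave open whether nitro would match chloro on the ring carbon that carries the chloro group in compound 1, where a single change of halogen already moved the number beyond the scatter.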